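A few compounds are considered here, and "the series" means these few. Any claim that something is new, unique, unknown or untested is made for them only; others in the source may bear on it.

Working notes on the series in a functional assay on HT-29 cells (Homo sapiens) for antiproliferative activity, read by MTT assay, with a stated time of 48 h; on this read-out lower numbers stand for stronger inhibition and higher numbers for weaker inhibition. Compound 2, `COc1ccc(/C=N/c2c(C#N)ncn2-c2ccc(F)cc2)cc1OC`, gives 7230 nM in this assay. Compound 1, `COc1cc(/C=N/c2c(C#N)ncn2-c2ccc(F)cc2)cc(OC)c1OC`, differs from compound 2 by methoxy in place of hydrogen on an aromatic carbon; in this assay compound 1 gives 13700 nM, and the step is a 1.9-fold higher number from compound 2 to compound 1 (0.28 log units; within the scatter). Compound 3, `COc1ccc(/C=N/c2c(C#N)ncn2Cc2ccc(F)cc2)cc1OC`, carries a different core, the difference being (4-fluorobenzyl in place of 4-fluorophenyl on an aromatic nitrogen); in this assay compound 3 gives 13800 nM, and the step is a 1.9-fold higher number from compound 2 to compound 3 (0.28 log units; within the scatter). Compound 4, `COc1ccc(/C=N/c2c(C#N)ncn2Cc2ccc(F)cc2)c(OC)c1OC`, is not yet measured. It differs from compound 3 by methoxy in place of hydrogen on an aromatic carbon, the same kind of change as that from compound 2 to compound 1, though the place is not identical: in compound 4 the entering methoxy is ortho to a large group, ortho to a methoxy group and meta to a methoxy group, whereas in compound 1 it is ortho to a methoxy group, meta to a large group and meta to a methoxy group. Going by the values given here, the one measured instance, a 1.9-fold higher number from compound 2 to compound 1 (0.28 log units; within the scatter), stayed within the scatter, so a comparably small step is expected here: a 1.4-fold higher number from compound 3 to compound 4 (0.16 log units; within the scatter), resting on that single precedent alone. Compound 4 is accordingly estimated at about 20000 nM in this assay, plausibly between 9000 nM and 45000 nM.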

Compound 4, half-maximal inhibitory concentration: > 25000 nM
Compound 4: only a limit was reported; the forecaster's own chance of this, stated with the estimate: 15%; at least 1.2-fold (0.09 log units) between middle value and limit.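

Compound 4 gives > 25000 nM in this assay; this is a limit of the assay and not a number. Read as a floor, the step is an at least 1.8-fold higher number from compound 3 to compound 4 (0.25 log units; that floor lies within the scatter), and nothing in it goes against methoxy in place of hydrogen carrying over from the core of compound 2 to the core of compound 3, although the entering methoxy does not stand in the same place on the two cores. It does not show that the change keeps its size from one core to the other: the same change on two cores in this assay, a 1.9-fold higher number (0.28 log units; within the scatter) from compound 2 to compound 1 and an at least 1.8-fold higher number (0.25 log units; that floor lies within the scatter) from compound 3 to compound 4; the limit leaves it open whether they differ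

From the compounds shown here alone, how far the true figure for compound 4 lies past the limit stays open: the limit of > 25000 nM in this assay, at which 1 of the 4 values shown sits. Also open is how a hydroxyl, an amine or a carboxylic acid in place of that methoxy would read, and how a methoxy in the place it holds in compound 4 would read on the core of compound 2.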